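Carbamoyl to (trifluoromethyl)sulfanyl: an expected cytotoxicity step

The compounds below may be only part of what the source reports. "The series", "measured", "known", "first", "only" and "open" are said of these compounds alone.

Compound 1 `Cc1ccc(NC(=O)Nc2cc(C)nc3ccccc23)cc1`: > 25000 nM, a limit
Compound 2 `COC(=O)c1ccc(NC(=O)Nc2cc(C)nc3ccccc23)cc1`: 17000 nM
Compound 3 `Cc1cc(NC(=O)Nc2ccc(C(N)=O)cc2)c2ccccc2n1`: > 25000 nM, a limit

All three results come from an ADME assay on Raji cells (Homo sapiens) for cytotoxicity, with a stated time of 72 h; on this read-out lower numbers stand for an effect already at smaller amounts and higher numbers for an effect only at larger amounts of compound. Compound 3 sits at the limit of > 25000 nM in this assay, at which 2 of the 3 values shown sit, so it has a limit and not a number.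

Compound 4 `Cc1cc(NC(=O)Nc2ccc(SC(F)(F)F)cc2)c2ccccc2n1` puts (trifluoromethyl)sulfanyl in place of carbamoyl on an aromatic carbon. Within the data shown here, no measured step makes this exact exchange, so the nearest guides are the three steps that alter the same substituent. The data show an at least 1.4-fold lower number from compound 1 to compound 2 (0.16 log units; that floor lies within the scatter), and also an at least 1.4-fold higher number from compound 2 to compound 3 (0.16 log units; that floor lies within the scatter). The third is a step that the two limits leave unreadable from compound 1 to compound 3. None of these shows a change beyond the scatter, and only compound 2 gives a number, 17000 nM. On the strength of an at least 1.4-fold lower number from compound 1 to compound 2 (0.16 log units; that floor lies within the scatter), only a modest move towards a lower number is expected, and it may stay within the scatter. The expected size is an at least 1.6-fold lower number from compound 3 to compound 4 (0.22 log units; that floor lies within the scatter). For compound 4, the estimated value is 15000 nM, with an expected range of 5000 nM to 25000 nM.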

Compound 4, half-maximal effective concentration: 10000 nM
The estimate for compound 4 lay 1.5-fold (0.18 log units) above the measured number; the measured number falls inside the stated range.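

In this assay, changing the group on this aromatic carbon, para to a large group, can now move the number beyond the scatter: (trifluoromethyl)sulfanyl gives an at least 2.5-fold lower number from compound 3 to compound 4 (0.39 log units; beyond the scatter) when carbamoyl leaves, and an at least 2.5-fold lower number from compound 1 to compound 4 (0.39 log units; beyond the scatter) when methyl leaves. Set against methoxycarbonyl, the same group gives a 1.7-fold lower number from compound 2 to compound 4 (0.23 log units; within the scatter) and so does not separate these two compounds. The two steps beyond the scatter start from limits, so they give only a floor and not a full size: the limit of > 25000 nM in this assay, at which 2 of the 4 values shown sit.

From the compounds shown here alone, whether a carboxylic acid, an amine or a nitrile at this place would give a number like that of (trifluoromethyl)sulfanyl or a limit like that of carbamoyl stays open. Also open, going by these compounds, is whether any group here could bring the number much lower than the values seen so far.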